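Inverting the ring stereocentre: from compound 2 to compound 3

The compounds below may be only part of what the source reports. "The series", "measured", "known", "first", "only" and "open" are said of these compounds alone.

Measured so far:
compound 1, `CC(C)(C)OC(=O)N1CCN(c2ncc(-c3ccc(OCC#N)cc3)cn2)CC1`: 81%
compound 2, `C[C@@H]1CN(c2ncc(OCc3ccc(S(C)(=O)=O)cc3)cn2)CCN1C(=O)OC(C)(C)C`: 106%

Both compounds were run in an in vitro functional assay on HEK293S cells with Glucose-dependent insulinotropic receptor (Homo sapiens) as the target, read by HTRF and cAMP accumulation, with a stated time of 45 min; a lower number here means a smaller maximal response, a higher number a larger maximal response. Compound 1 gives 81% and compound 2 gives 106%. Of the two numbers, compound 2 stands higher, and the gap to compound 1 lies beyond the usual scatter of this assay, so compound 2 is the larger responder of the pair on the data at hand.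

Compound 3, `C[C@H]1CN(c2ncc(OCc3ccc(S(C)(=O)=O)cc3)cn2)CCN1C(=O)OC(C)(C)C`, is the next candidate. Its difference from compound 2 is counted as the two compounds have the same atoms and bonds and differ only in configuration as drawn: 1 of 1 stereo elements differ; a stereocentre at a saturated ring carbon is drawn R in compound 2 and S in compound 3. Among the compounds with values here, no pair of measured compounds differs in only one place, so nothing itself says how large a step a change of configuration brings in this assay; an inverted stereocentre can leave the maximal response unchanged or lower it noticeably.

Weighing this, the step from compound 2 to compound 3 is expected to be a modest decrease, a number 16 percentage points lower from compound 2 to compound 3 (beyond the scatter), near the edge of the scatter. Compound 3 is therefore estimated at 90%, with a range from 55% to 115%.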

Compound 3, intrinsic activity: the largest response reached, in percent of the reference agonist's in the Glucose-dependent insulinotropic receptor assay: 163%
Beside the measured number, compound 3's estimate is 73 percentage points below it; measured number above the stated range.
By their numbers in the Glucose-dependent insulinotropic receptor assay, from the lowest: compound 1; then compound 2; then compound 3.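

Within the data shown here, in the Glucose-dependent insulinotropic receptor assay, this is the first pair that differs in one place, and it shows that the configuration at the saturated ring carbon by itself matters, with a number 57 percentage points higher from compound 2 to compound 3 (beyond the scatter) and the larger maximal response belonging to the form drawn S; the step can be assigned to that inversion alone, since no other part of the structure changes: the fact that compounds 2 and 3 differ only in the configuration as drawn.

In a physicochemical assay for lipophilicity, using the shake flask method, in phosphate buffer, measured as octanol-water partition, at pH 7.4 (a lower number here means a more polar compound, a higher number a more lipophilic compound), compound 2 gives > 3.7, which is a limit of the assay and not a number. In the physicochemical assay compound 3 gives > 3.6, which is likewise a limit and not a number.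

On these data alone, with both values given as limits, the step between the two compounds cannot be read, so whether the inversion changes the distribution coefficient at all remains open. Also open, as far as these compounds go, is whether the preference for the form drawn S persists when the methyl group on the ring carbon is replaced by an ethyl group, or when the methylsulfonyl group gives way to a carboxylic acid or an amine.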